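The source may report more compounds than this note shows. Statements on the series, on what has been measured and on what is new or still open speak of the compounds shown alone.

In an ADME assay on microsomes from liver (Homo sapiens) for metabolic stability, with a stated time of 60 min, tested at 1 uM (on this read-out higher numbers stand for a more stable compound and lower numbers for a less stable compound), compound 3 `COc1cn2ncc(-c3ccnc(OC4CC4)c3)c2nc1-c1cnn(C)c1` gives 47% and lies within the scatter of both measured relatives: compound 1 `COc1cc(-c2cnn3cc(OC)c(-c4cnn(C)c4)nc23)ccn1` gives 43% and compound 2 `Cn1cc(-c2nc3c(-c4ccnc(OC5CC5)c4)cnn3cc2OCCCC(C)(C)O)cn1` gives 54%. Compound 4 `Cn1cc(-c2nc3c(-c4ccnc(OC5CC5)c4)cnn3cc2OCC(C)(C)O)cn1` has 1-hydroxy-1-methylethyl in place of hydrogen on a saturated chain carbon bound to an oxygen on an aromatic ring, so methoxy becomes 2-hydroxy-2-methylpropoxy. The most relevant measured step alters that same carbon, where 3-hydroxy-3-methylbutyl gives way to hydrogen (a number 7 percentage points lower from compound 2 to compound 3 (within the scatter)). Read in reverse, this step points to a small upward shift, but one that stays within the scatter. The other step, with cyclopropyl in place of methyl on an oxygen on an aromatic ring (a number 4 percentage points higher from compound 1 to compound 3 (within the scatter)), concerns a different group and offers little guidance here. No change beyond the scatter is therefore expected, and the estimated step is small (a number 4 percentage points higher from compound 3 to compound 4 (within the scatter)). Compound 4 is expected to give about 51% (estimated range 39% to 63%).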

Compound 4, percent of the compound remaining: 53%
Compound 4: middle estimate off by 2 percentage points, on the low side; the measured number falls inside the stated range.
By their numbers in this assay, from the lowest: compounds 1, 3, 4 and 2 (each within the scatter of the next, the first and the last beyond it).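

On a saturated chain carbon bound to an oxygen on an aromatic ring, placing 1-hydroxy-1-methylethyl in place of hydrogen leaves this assay without a step beyond the scatter (a number 6 percentage points higher from compound 3 to compound 4 (within the scatter)). Setting 1-hydroxy-1-methylethyl in place of 3-hydroxy-3-methylbutyl at that carbon does the same (a number 1 percentage points lower from compound 2 to compound 4 (within the scatter)), so compound 2, compound 3 and compound 4 cannot be told apart on this read-out, whether the oxygen carries methoxy or either of the two hydroxy-bearing chains. No measurement shown here explains this result.

Going by these compounds, whether an amine or a carboxylic acid in place of the hydroxyl on this chain would move the number beyond the scatter remains open. Also open, on these data alone, is whether 2-hydroxy-2-methylpropoxy would read the same on compound 1, which has methyl rather than cyclopropyl on its other oxygen.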